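Moving the Fluorine on the Sulfonyl Ring

The source may report more compounds than this note shows. Statements on the series, on what has been measured and on what is new or still open speak of the compounds shown alone.

Compound 1 `Cc1ccccc1C(=O)NCc1ccc(CNS(=O)(=O)c2cccc(Cl)c2)cc1`: 100 nM
Compound 2 `Cc1ccccc1C(=O)NCc1ccc(CNS(=O)(=O)c2ccc(F)cc2)cc1`: 10 nM

Of the compounds shown here, two have been measured in an assay on MDA-MB-231 cells for displacement of a labelled ligand from C-X-C chemokine receptor type 4 (Homo sapiens), read by fluorescence and microscopy, with stated times of 10 min and 30 min; a lower number here means that less compound is needed, a higher number that more compound is needed for the effect. Compound 2 stands at the lower of the two numbers, and its neighbour compound 1 sits at a higher one: a 10-fold lower number from compound 1 to compound 2 (1.00 log units; beyond the scatter). For the measured compounds named here, that single step is the only measured comparison, and it changes both the halogen and its place on the ring at once, so it bears only loosely on the next move. Compound 3 `Cc1ccccc1C(=O)NCc1ccc(CNS(=O)(=O)c2cccc(F)c2)cc1` is now to be measured in this assay; its change from compound 2 is 3-fluorophenyl in place of 4-fluorophenyl on a sulfonyl sulfur. Because the step of a 10-fold lower number from compound 1 to compound 2 (1.00 log units; beyond the scatter) joined a change of ring position to a change of halogen, compound 3 is expected to land between the two measured compounds, with a modest rise from compound 2: a 3.0-fold higher number from compound 2 to compound 3 (0.48 log units; beyond the scatter). For compound 3 the estimate in this assay is 30 nM, with a range from 8 nM to 120 nM.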

Compound 3, effective concentration (reported as EC, without a stated level of effect): 100 nM
The estimate for compound 3 lay 3.3-fold (0.52 log units) below the measured number, and the stated range covers the measured number.
By their numbers in this assay, from the lowest: compound 2; then compounds 1 and 3 (each within the scatter of the next).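

Compound 3 pulls apart the two changes that the earlier step joined. Moving the fluorine alone, with 3-fluorophenyl in place of 4-fluorophenyl on the sulfonyl sulfur, gives a 10-fold higher number from compound 2 to compound 3 (1.00 log units; beyond the scatter) in this assay, while exchanging the halogen alone, with fluoro in place of chloro on an aromatic carbon, gives no change at the digits printed from compound 1 to compound 3 (within the scatter) and so leaves the number unmoved. Among these three compounds the difference therefore follows the place of the halogen on the ring and not its identity, although nothing available here explains why.

From the compounds shown here alone, it remains open whether chloro would also match fluoro in the setting of the 4-fluorophenyl group of compound 2. Going by these compounds, how the number would respond to a methoxy group or an amine in place of the halogen also remains unknown.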